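The compounds below may be only part of what the source reports. "The series", "measured", "known", "first", "only" and "open" are said of these compounds alone.

Values so far in a functional assay on HeLa cells (Homo sapiens) for inhibition, read by MTT assay, with a stated time of 72 h; a lower number here means a stronger inhibitor, a higher number a weaker inhibitor:

compound 1 `Oc1ccc(-c2nnc(SCCCN3CCN(c4nc5ccccc5o4)CC3)o2)cc1` gives 99500 nM
compound 2 `O=[N+]([O-])c1ccc(-c2nnc(SCCCN3CCN(c4nc5ccccc5s4)CC3)o2)cc1` gives 97800 nM
compound 3 `Brc1ccc(-c2nnc(SCCCN3CCN(c4nc5ccccc5s4)CC3)o2)cc1` gives 243000 nM

Compound 3 has the highest of the three numbers, and compound 1 and compound 2 both lie lower by margins beyond the scatter. The next compound is compound 4 `Oc1ccc(-c2nnc(SCCCN3CCN(c4nc5ccccc5s4)CC3)o2)cc1`, which differs from compound 3 as follows: hydroxy in place of bromo on an aromatic carbon. In short, this is hydroxy in place of bromo on an aromatic carbon.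

Within the data shown here, no measured step makes this exact change. The closest is a 2.5-fold higher number from compound 2 to compound 3 (0.40 log units; beyond the scatter), a modest step with bromo in place of nitro on an aromatic carbon. It shows that the number for the bromo compound can move beyond the scatter on a change at this carbon. Compound 1 also carries the 4-hydroxyphenyl group, with a value of 99500 nM, but it differs from compound 4 elsewhere in the core, so it offers only indirect support.

A modest step toward a lower number in this assay is therefore expected, though with little evidence behind it. The expected change is a 2.2-fold lower number from compound 3 to compound 4 (0.34 log units; beyond the scatter). Compound 4 is estimated at 110000 nM, with an expected range from 55000 nM to 230000 nM.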

Compound 4, half-maximal inhibitory concentration: 139000 nM
Estimate against measurement, compound 4: 1.3-fold (0.10 log units) below; low and high end bracket the measured number.
By their numbers in this assay, from the lowest: compounds 2, 1, 4 and 3 (each within the scatter of the next, the first and the last beyond it).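

In this assay, the change from 4-bromophenyl to 4-hydroxyphenyl (a 1.7-fold lower number from compound 3 to compound 4 (0.24 log units; within the scatter)) and hydroxy in place of nitro (a 1.4-fold higher number from compound 2 to compound 4 (0.15 log units; within the scatter)) both stay within the scatter, so at this aromatic carbon the hydroxy compound cannot be separated from either the bromo or the nitro compound, even though those two are separated from each other (a 2.5-fold higher number from compound 2 to compound 3 (0.40 log units; beyond the scatter)). Among these compounds, with the 4-hydroxyphenyl group held constant, the first single-place comparison at the other end of the molecule, 1,3-benzothiazol-2-yl in place of 1,3-benzoxazol-2-yl on the ring amine nitrogen, also cannot be told from the scatter (a 1.4-fold higher number from compound 1 to compound 4 (0.15 log units; within the scatter)). Among the compounds shown here, no supporting data are available to explain these values or the one step that lies beyond the scatter.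

Still open, as far as these compounds go, is whether an amino or methoxy group on this aromatic carbon would stay within the scatter of compound 4 or move clearly away from it. Also open, from the compounds shown here alone, is whether a longer chain in place of the present linker, or a 1,3-benzoxazol-2-yl group paired with the bromo or nitro substituent, would change the number in this assay.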